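The source may hold more compounds than are shown below. What is called first, only, known or untested is meant among the compounds shown, and "the series" means these compounds.

Measured in a physicochemical assay for solubility, in phosphate buffer, at pH 7.4; a lower number here means a less soluble compound, a higher number a more soluble compound:
- compound 1 `CC(=O)N[C@@H]1CCC[C@H](C(=O)Nc2cc(-c3cnc(C)n3C)c(Cl)cn2)C1`: > 1000000 nM (a limit of the assay, not a number)
- compound 2 `CC(=O)N[C@@H]1CCC[C@H](C(=O)Nc2cc(-c3cnn4c3CCC4)c(Cl)cn2)C1`: 160000 nM
- compound 3 `CC(=O)N[C@@H]1CCC[C@H](C(=O)Nc2cc(-c3cnn4c3CCCCC4)c(Cl)cn2)C1`: 104000 nM

Compound 3 stands level with compound 2 in this assay, as a 1.5-fold lower number from compound 2 to compound 3 (0.19 log units; within the scatter) shows. Both have numbers beyond the scatter from the limit of compound 1.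

The next compound is compound 4 `CC(=O)N[C@@H]1CCC[C@H](C(=O)Nc2cc(-c3cnn4c3OCCC4)c(Cl)cn2)C1`. The change from compound 3 is a group of 9 heavy atoms (6 carbon, 2 nitrogen, 1 oxygen; one five-membered aromatic ring with 2 hetero atoms, one six-membered non-aromatic ring with 2 hetero atoms) in place of a group of 10 heavy atoms (8 carbon, 2 nitrogen; one five-membered aromatic ring with 2 hetero atoms, one seven-membered non-aromatic ring with 1 hetero atom), on an aromatic carbon. It sits on an aromatic carbon of a six-membered aromatic ring, ortho to a chloro group.

Among the measured compounds shown here, three measured steps bear on it. Both an at least 6.2-fold lower number from compound 1 to compound 2 (0.79 log units; beyond the scatter) and an at least 9.6-fold lower number from compound 1 to compound 3 (0.98 log units; beyond the scatter) bring in a group with a non-aromatic ring. Going from a five-membered to a seven-membered non-aromatic ring gave a 1.5-fold lower number from compound 2 to compound 3 (0.19 log units; within the scatter). For the measured compounds named here, no measured step covers the added oxygen. Compound 4 also carries a non-aromatic ring, of a size between those two, so the closest guide is a 1.5-fold lower number from compound 2 to compound 3 (0.19 log units; within the scatter).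

The expected result is no change beyond the scatter, with a 1.6-fold higher number from compound 3 to compound 4 (0.21 log units; within the scatter) as the estimated step. For compound 4 the estimated value is 170000 nM, with an expected range of 70000 nM to 500000 nM.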

Compound 4, solubility: 110000 nM
For compound 4 the middle estimate is 1.5-fold (0.19 log units) above the measured one; low and high end bracket the measured number.
By their numbers in this assay, from the lowest: compounds 3, 4 and 2 (each within the scatter of the next). At a limit, above all of these: compound 1.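

In this assay, the group with an oxygen in its six-membered non-aromatic ring reads level with both all-carbon-linked neighbours: a 1.1-fold higher number from compound 3 to compound 4 (0.02 log units; within the scatter) and a 1.5-fold lower number from compound 2 to compound 4 (0.16 log units; within the scatter). At this position, ortho to a chloro group, the five-, six- and seven-membered non-aromatic rings therefore cannot be told apart in this read-out, and the oxygen brings no step beyond the scatter. Compound 1 stands at a limit of the assay, not a number, so an at least 9.0-fold lower number from compound 1 to compound 4 (0.95 log units; beyond the scatter) is only a bound, the third such bound from that compound: the limit of > 1000000 nM in this assay, at which 1 of the 4 values shown sits.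

As far as these compounds go, compound 4 differs from compound 2 and compound 3 in both ring size and oxygen, so the part played by the oxygen alone stays open. Also open, from the compounds shown here alone, is how this assay responds to an amine or a carboxylic acid on the non-aromatic ring.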